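Swapping the Oxazole Substituent in an Amide Hydrolase Inhibitor Series

The compounds below may be only part of what the source reports. "The series", "measured", "known", "first", "only" and "open" are said of these compounds alone.

Of the compounds shown here, three have been measured so far in an assay for inhibition of Fatty-acid amide hydrolase 1 (Rattus norvegicus); on this read-out higher numbers stand for weaker inhibition and lower numbers for stronger inhibition. Compound 1, `CS(=O)(=O)c1cnc(C(=O)CCc2ccc(-c3ccccc3)cc2)o1`, gives 1.2 nM. Compound 2, `N#Cc1cccc(-c2cnc(C(=O)CCc3ccc(COc4ccccc4)cc3)o2)n1`, gives 0.56 nM, and compound 3, `O=C(CCc1ccc(-c2ccccc2)cc1)c1ncc(-c2cccc(-c3nnn[nH]3)n2)o1`, gives 25 nM. On these numbers compound 1 stands second highest of the three: compound 2 sits at a lower number, beyond the usual scatter, while compound 3 sits far higher, the furthest from compound 1 in this set. Going by the values given here, the three compounds differ from one another in more than one place, so no single step between them can be separated out.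

Compound 4, `O=C(CCc1ccc(-c2ccccc2)cc1)c1ncc(C(=O)C(F)(F)F)o1`, is not yet measured. It differs from compound 1 in one place only: (trifluoromethyl)carbonyl in place of methylsulfonyl on an aromatic carbon. Both groups are small, carry no charge and sit on the same aromatic carbon of the shared core. With no measured step of this kind in the set, the expectation is that the step from compound 1 to compound 4 in this assay is modest, most likely a small rise in the number, and it may fall within the scatter; the expected step is a 2.5-fold higher number from compound 1 to compound 4 (0.40 log units; beyond the scatter). Compound 4 is therefore estimated to give 3 nM in this assay, with a range from 0.6 nM to 15 nM.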

Compound 4, inhibition constant: 8 nM
Beside the measured number, compound 4's estimate is 2.7-fold (0.43 log units) below it; measured number inside the range.
By their numbers in this assay, from the lowest: compound 2; then compound 1; then compound 4; then compound 3.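

Going by these compounds alone, this is the first change in the set that can be read at a single place: in this assay, (trifluoromethyl)carbonyl in place of methylsulfonyl on an aromatic carbon gives a 6.7-fold higher number from compound 1 to compound 4 (0.82 log units; beyond the scatter). The position next to the ring oxygen therefore responds to the exchange, even though neither group has a ring, a hydrogen-bond donor or a net charge. The two groups do differ in their heavy atoms, double bonds and hydrogen-bond acceptors, but no measurement here shows which difference, if any, accounts for the higher number.

Going by these compounds, it remains open whether a carboxylic acid, an amine or a longer chain at this same aromatic carbon would give a number closer to that of compound 1 or to that of compound 4. Also open, on these data alone, is whether the same exchange would give a step of similar size with the different large group of compound 2 in place, since a single pair cannot show whether the effect carries over to another part of the series.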